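Extending the Oxime Chain of an Aryloxyacetic Acid

The source may hold more compounds than are shown below. What is called first, only, known or untested is meant among the compounds shown, and "the series" means these compounds.

Compound 2 `C/C(CC1CCc2c(cccc2OCC(=O)O)C1)=N\OC(c1ccccc1)c1cccnc1` gives 20000 nM in an assay for inhibition of Thromboxane-A synthase (Homo sapiens), using microsomes (a lower number here means a stronger inhibitor, a higher number a weaker inhibitor), the lowest of the two numbers measured in this series. Its nearest neighbour is compound 3 `C/C(CC1CCc2c(cccc2OCC(=O)O)C1)=N\OC(c1ccccc1)c1ccncc1`, which in this assay gives 210000 nM; the step of an 11-fold higher number from compound 2 to compound 3 (1.02 log units; beyond the scatter) lies beyond the scatter. Compound 1 `O=C(O)COc1cccc2c1CCCC2CCC(=O)NN(c1ccccc1)c1ccccc1` is reported in this assay as "not active" (no number reported), with no number attached. Compound 4 `CCC/C(CC1CCc2c(cccc2OCC(=O)O)C1)=N\OC(c1ccccc1)c1cccnc1` differs from compound 2 in a single place: ethyl in place of hydrogen on a saturated chain carbon bound to a carbon with a double bond to nitrogen. Among the compounds with values here, none of the measured steps touches this position; the only step in hand concerns the pyridinyl group on the other side of the molecule and gives no guidance on a longer chain on the saturated chain carbon bound to the carbon with a double bond to nitrogen. With nothing to argue for a change in either direction, the expected step is no change at the digits printed from compound 2 to compound 4 (within the scatter), within the scatter. Compound 4 is therefore estimated at 20000 nM in this assay, with a range from 5000 nM to 80000 nM.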

Compound 4, half-maximal inhibitory concentration: 85000 nM
Estimate against measurement, compound 4: 4.3-fold (0.63 log units) below; the whole stated range lies below it.
By their numbers in this assay, from the lowest: compound 2; then compound 4; then compound 3.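

Within the data shown here, the earlier compounds spoke only to the pyridinyl group, so this is the first reading on the saturated chain carbon bound to a carbon with a double bond to nitrogen, and in this assay that position proves sensitive: ethyl in place of hydrogen there gives a 4.3-fold higher number from compound 2 to compound 4 (0.63 log units; beyond the scatter). Read alongside the large step of an 11-fold higher number from compound 2 to compound 3 (1.02 log units; beyond the scatter), this modest step moves the number in the same direction, so compound 2 keeps the lowest number of the three. Nothing available explains why the longer chain raises the number.

The compounds shown leave open whether the number climbs steadily with chain length, since only methyl and propyl stand at this place. On these data alone, how a butyl chain or a chain carrying an amine would read here also remains open.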